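Aryl swap on the sulfonyl of a shared core

A few compounds are considered here, and "the series" means these few. Any claim that something is new, unique, unknown or untested is made for them only; others in the source may bear on it.

Measured so far:
compound 1 `COc1ccc2ncc(S(=O)(=O)c3ccc(OC)c(OC)c3)c(N3CCC(C)CC3)c2c1`: -3%
compound 2 `Cc1ccc2ncc(S(=O)(=O)c3ccc(C#N)cc3)c(N3CCC(C)CC3)c2c1`: 55%
compound 3 `COCC1CCN(c2c(S(=O)(=O)c3cccc(F)c3)cnc3cc(F)ccc23)CC1`: 70.5%

All three numbers come from an assay on isolated protein for displacement of a labelled ligand from metabotropic glutamate receptor 5 (Homo sapiens), with a stated time of 60 min, tested at 1 uM; a lower number here means less inhibition, a higher number more inhibition at the concentration tested (going by the name of the read-out). Compound 2 stands second highest of the three. Compound 3 lies higher than compound 2, and that gap is beyond the usual scatter; compound 1 lies far lower than compound 2, also beyond the scatter. Compound 3 carries a fluorinated phenyl on its sulfonyl sulfur, compound 1 a dimethoxyphenyl, but both also differ from compound 2 elsewhere, so no single-point comparison exists among the measured compounds.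

Among the measured compounds shown here, compound 4 `Cc1ccc2ncc(S(=O)(=O)c3cc(F)cc(F)c3)c(N3CCC(C)CC3)c2c1` is the next compound for this assay. 3,5-difluorophenyl in place of 4-cyanophenyl on a sulfonyl sulfur No directly comparable step is recorded. The change is expected to move the read-out only modestly, with a slight upward lean given that compound 3, the only fluorinated aryl sulfone measured, gives 70.5%, but the confidence in the direction is low. The step from compound 2 to compound 4 is estimated at a number 3 percentage points higher from compound 2 to compound 4 (within the scatter). Compound 4 is expected to give 58%, with a plausible range from 30% to 82%.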

Compound 4, a percentage reported as inhibition, at one concentration (the size of the read-out at that concentration, not a potency): 72%
Compound 4: the middle estimate sits 14 percentage points below what was measured; low and high end bracket the measured number.
By their numbers in this assay, from the lowest: compound 1; then compound 2; then compounds 3 and 4 (each within the scatter of the next).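

In this assay, the series now has its first single-place comparison: with 3,5-difluorophenyl in place of 4-cyanophenyl on a sulfonyl sulfur, the read-out rises by a number 17 percentage points higher from compound 2 to compound 4 (beyond the scatter). This shows that the aryl group at this position can change the read-out by itself, with the rest of the molecule held constant, which compound 1, compound 2 and compound 3 could not show, as they differ in more than one place. Nothing available explains the size or direction of this step.

This single pair cannot separate the loss of the nitrile from the gain of fluorine. From the compounds shown here alone, a plain phenyl or a 3,5-dichlorophenyl on the same sulfonyl sulfur would bear on that, and whether the step carries over to other cores remains open.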